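A few compounds are considered here, and "the series" means these few. Any claim that something is new, unique, unknown or untested is made for them only; others in the source may bear on it.

Measured compounds:
Compound 1, `[SeH]c1nc([SeH])c2ccccc2n1`: in a functional assay on MCF7 cells (Homo sapiens) for cytotoxicity, read by MTT assay, with a stated time of 72 h (on this read-out lower numbers stand for stronger inhibition of growth and higher numbers for weaker inhibition of growth), compound 1 gives 22900 nM.
Compound 2, `Nc1nc([SeH])nc2ncccc12`: in this assay compound 2 gives > 100000 nM, which is a limit of the assay and not a number.

Compound 2 therefore stands on the limit of this assay, (the limit of > 100000 nM in this assay, at which 1 of the 2 values shown sits), and no number for it is in hand. Compound 3, `[SeH]c1nc([SeH])c2cccnc2n1`, is not yet measured. It differs from compound 2 by one selenium atom in place of one nitrogen atom, on an aromatic carbon; in words, one selenium atom in place of one nitrogen atom, on an aromatic carbon. Within the data shown here, no step between measured compounds is available, so the size of the change is open. Compound 3 bears only selenol groups on its core, as compound 1 does, and compound 1 gives 22900 nM in this assay. Resting on that, compound 3 is expected to come off the limit, with an estimated step of an at least 3.3-fold lower number from compound 2 to compound 3 (0.52 log units; beyond the scatter). The estimate for compound 3 is 30000 nM, expected to fall in the range 8000 nM to 100000 nM.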

Compound 3, concentration for total growth inhibition: 46100 nM
Estimate against measurement, compound 3: 1.5-fold (0.19 log units) below, within the range that was stated.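

Among these compounds, at this place, on an aromatic carbon next to the ring nitrogen, one selenium atom in place of the amino group gives the first step that can be read in this assay, an at least 2.1-fold lower number from compound 2 to compound 3 (0.33 log units; beyond the scatter). With this result the amino group stands on the weaker side of the exchange, and compound 3 gives a number at 46100 nM. The step is only a bound, and its full size stays open, as compound 2 carries a limit and not a number: the limit of > 100000 nM in this assay, at which 1 of the 3 values shown sits.

As far as these compounds go, how a thiol, a hydroxyl group or a methylamino group would compare at this place remains open. From the compounds shown here alone, whether the same exchange would give a step of like size on the core of compound 1 also remains open.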